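A few compounds are considered here, and "the series" means these few. Any claim that something is new, unique, unknown or untested is made for them only; others in the source may bear on it.

Working notes on the series.

In an ADME assay on Vero cells (Chlorocebus sabaeus) for cytotoxicity, read by MTT assay, with a stated time of 96 h (a lower number here means that less compound is tolerated, a higher number that more compound is tolerated), compound 2 `C/C(=N\NC(N)=S)c1ccc2c(c1)nc(-c1ccccc1)n2C1CCCCC1` gives 20000 nM and compound 3 `C/C(=N\NC(N)=S)c1ccc2c(c1)nc(-c1ccoc1)n2C1CCCCC1` gives 25000 nM. For compound 1 `C/C(=N\NC(N)=S)c1ccc2[nH]c(-c3ccccc3)nc2c1` the result in this assay is a limit, > 100000 nM, as set out in the limit of > 100000 nM in this assay, at which 1 of the 3 values shown sits. The change hydrogen in place of cyclohexyl on an aromatic nitrogen produced an at least 5.0-fold higher number from compound 2 to compound 1 (0.69 log units; beyond the scatter). The change furan-3-yl in place of phenyl on an aromatic carbon produced a 1.3-fold higher number from compound 2 to compound 3 (0.10 log units; within the scatter), so compounds 2 and 3 stand together.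

Compound 4 `C/C(=N\NC(N)=S)c1ccc2[nH]c(-c3ccoc3)nc2c1` is not yet measured in this assay. It differs from compound 3 by hydrogen in place of cyclohexyl on an aromatic nitrogen, the same kind of change as that from compound 2 to compound 1, though here the ring atom next to the nitrogen bears a furan-3-yl group rather than a phenyl group; the two cores differ by furan-3-yl in place of phenyl on an aromatic carbon. Given an at least 5.0-fold higher number from compound 2 to compound 1 (0.69 log units; beyond the scatter), a step of a 4.0-fold higher number from compound 3 to compound 4 (0.60 log units; beyond the scatter) is expected, and compound 4 is estimated at 100000 nM, between 40000 nM and 300000 nM, quite possibly reported only as a limit in this assay.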

Compound 4, half-maximal cytotoxic concentration: 100000 nM
Compound 4: middle estimate and measured number agree at the digits printed, and the stated range covers the measured number.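

Hydrogen in place of cyclohexyl on an aromatic nitrogen again gives a higher number in this assay, with a 4.0-fold higher number from compound 3 to compound 4 (0.60 log units; beyond the scatter). The direction of the change therefore carries from one core to the other in these two pairs, but whether its size carries over stays unsettled: the same change on two cores in this assay, an at least 5.0-fold higher number (0.69 log units; beyond the scatter) from compound 2 to compound 1 and a 4.0-fold higher number (0.60 log units; beyond the scatter) from compound 3 to compound 4; the limit leaves it open whether they differ

Furan-3-yl in place of phenyl on an aromatic carbon gives a number no higher from compound 1 to compound 4 (the limit leaves the size open) but the size of this step cannot be read, since the value of compound 1 is a limit: the same change on two cores in this assay, a 1.3-fold higher number (0.10 log units; within the scatter) from compound 2 to compound 3 and a number no higher (the limit leaves the size open) from compound 1 to compound 4; the limit leaves it open whether they differ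

The compounds shown carry only hydrogen or cyclohexyl on that nitrogen, and only phenyl or furan-3-yl on the aromatic carbon. On these data alone, it remains open where an ethyl group or a chain ending in an amine on that nitrogen would fall relative to compound 3 and compound 4.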